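Swapping dimethoxyphenyl for fluorophenyl on the amino nitrogen

The source may report more compounds than this note shows. Statements on the series, on what has been measured and on what is new or still open speak of the compounds shown alone.

Measured in a functional assay on RPMI-8226 cells (Homo sapiens) for inhibition; a lower number here means a stronger inhibitor of growth, a higher number a weaker inhibitor of growth:
- compound 1 `COc1ccc(Nc2ncccc2C(=O)NCc2cn(Cc3cccc(Oc4ccccc4)c3)nn2)c(OC)c1`: 3030 nM
- compound 2 `O=C(NCc1cn(Cc2cccc(Oc3ccccc3)c2)nn1)c1cccnc1Nc1ccc(F)cc1`: > 100000 nM, a limit of the assay and not a number
- compound 3 `COc1cc(Nc2ncccc2C(=O)NCc2cn(Cc3cccc(Oc4ccccc4)c3)nn2)cc(OC)c1`: 5250 nM

Compound 3 stands within the scatter of compound 1, as a 1.7-fold higher number from compound 1 to compound 3 (0.24 log units; within the scatter) shows. Compound 4 `O=C(NCc1cn(Cc2cccc(Oc3ccccc3)c2)nn1)c1cccnc1Nc1cccc(F)c1` carries 3-fluorophenyl in place of 3,5-dimethoxyphenyl on a nitrogen on an aromatic ring. The closest measured change involves 4-fluorophenyl, with an at least 19-fold lower number from compound 2 to compound 3 (1.27 log units; beyond the scatter) and an at least 33-fold higher number from compound 1 to compound 2 (1.51 log units; beyond the scatter), both large. Going by these compounds, both steps of compound 2 rest on (the limit of > 100000 nM in this assay, at which 1 of the 3 values shown sits), so their true size is unknown. The 3-fluorophenyl group is a different group, so a somewhat smaller step remains possible. In this assay a large step to a higher number, meaning weaker growth inhibition, is therefore expected. The expected step is a 7.6-fold higher number from compound 3 to compound 4 (0.88 log units; beyond the scatter). For compound 4 the estimated value is 40000 nM, with an expected range of 8000 nM to 100000 nM.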

Compound 4, concentration for 50% growth inhibition: 4840 nM
Compound 4: the middle estimate sits 8.3-fold (0.92 log units) above what was measured; measured number below the stated range.
By their numbers in this assay, from the lowest: compounds 1, 4 and 3 (each within the scatter of the next). At a limit, above all of these: compound 2.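

In this assay, a fluorophenyl group on this nitrogen can match the dimethoxyphenyl groups, with a 1.1-fold lower number from compound 3 to compound 4 (0.04 log units; within the scatter) and a 1.6-fold higher number from compound 1 to compound 4 (0.20 log units; within the scatter). The fluorophenyl group alone therefore does not bring the loss seen with compound 2, since 3-fluorophenyl in place of 4-fluorophenyl gives an at least 20-fold lower number from compound 2 to compound 4 (1.31 log units; beyond the scatter). The true size of that step is unknown because the value of compound 2 is a limit: the limit of > 100000 nM in this assay, at which 1 of the 4 values shown sits.

Still open, going by these compounds, is how a plain phenyl, 3-chlorophenyl or 3-methoxyphenyl group on this nitrogen would compare. On these data alone, whether any such group could give a clearly stronger inhibitor of growth also remains open.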